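Estimating the Lipophilicity of a Bromo-Methoxy Analogue

This account rests on a few compounds, and the source may have more. Where it says the series, first, only, none or still open, it means among the compounds named here.

Measured in a physicochemical assay for lipophilicity; a lower number here means a more polar compound, a higher number a more lipophilic compound:
- compound 1 `COc1ccc(C2=NO[C@]3(C2)C(=O)O[C@@H]2[C@H]3CC[C@H](C)[C@]3(O)C=CC(=O)[C@@]23C)cc1OC`: 1.06
- compound 2 `C[C@H]1CC[C@@H]2[C@@H](OC(=O)[C@]23CC(c2cccc([N+](=O)[O-])c2)=NO3)[C@]2(C)C(=O)C=C[C@@]12O`: 1.37
- compound 3 `Cc1ccc(C2C[C@@]3(ON2c2ccccc2)C(=O)O[C@@H]2[C@H]3CC[C@H](C)[C@]3(O)C=CC(=O)[C@@]23C)cc1`: 3.64

Compound 3 has the highest number of the three, clearly beyond the scatter of both others. Compound 4 `COc1ccc(C2C[C@@]3(ON2c2ccccc2)C(=O)O[C@@H]2[C@H]3CC[C@H](C)[C@]3(O)C=CC(=O)[C@@]23C)cc1Br` is built from compound 3 by one change: 3-bromo-4-methoxyphenyl in place of 4-methylphenyl on a saturated ring carbon.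

For the measured compounds named here, only one measured step swaps one substituted phenyl group for another: a number 0.31 log units higher from compound 1 to compound 2 (beyond the scatter). There, 3-nitrophenyl replaces 3,4-dimethoxyphenyl on a carbon with a double bond to nitrogen. That is a different kind of carbon and a different pair of groups, so this step is only a loose guide. It does suggest a modest size rather than a large one, and the data do not settle the direction. A modest rise in this assay is the best guess, and the expected step is a number 0.36 log units higher from compound 3 to compound 4 (beyond the scatter). Compound 4 is estimated at 4, with an expected range from 3.5 to 4.5.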

Compound 4, partition coefficient: 3.98
The estimate for compound 4 lay 0.02 log units above the measured number; low and high end bracket the measured number.
By their numbers in this assay, from the lowest: compound 1; then compound 2; then compound 3; then compound 4.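

In this assay, putting 3-bromo-4-methoxyphenyl in place of 4-methylphenyl on the saturated ring carbon gives a number 0.34 log units higher from compound 3 to compound 4 (beyond the scatter) and is the only step shown at this position. The entering group counts one hydrogen-bond acceptor where the leaving group counts none, yet for this pair the number still rises, which gives a direction that the earlier step on a different kind of carbon could not supply. No measurement on hand explains the rise.

Bromine and methoxy arrive together, so the compounds shown cannot split the step between them, and a phenyl group carrying only one of the two would be needed for that. On these data alone, how the number would move with an amine or a carboxylic acid on the phenyl ring at this position also stays open.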